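This account rests on a few compounds, and the source may have more. Where it says the series, first, only, none or still open, it means among the compounds named here.

Measured compounds in a functional assay on HeLa cells (Homo sapiens) for inhibition, read by MTT assay, with a stated time of 72 h; on this read-out higher numbers stand for weaker inhibition and lower numbers for stronger inhibition:
- Compound 1 `COc1ccc(/C=C/C(=O)c2c(OC)cc(O)c(CC=C(C)C)c2O)cc1`: compound 1 gives only the limit > 50000 nM.
- Compound 2 `COc1ccccc1/C=C/C(=O)c1c(OC)cc(O)c(CC=C(C)C)c1O`: compound 2 gives 19700 nM.
- Compound 3 `COc1ccc(/C=C/C(=O)c2c(OC)cc(O)c(CC=C(C)C)c2O)cc1OC`: compound 3 gives 27700 nM.

Among the measured compounds shown here, compound 1 stands at a limit of this assay and not at a number; it is the one of the three values that sits there (the limit of > 50000 nM in this assay, at which 1 of the 3 values shown sits). Both measured steps away from it lower the number: an at least 2.5-fold lower number from compound 1 to compound 2 (0.40 log units; beyond the scatter) and an at least 1.8-fold lower number from compound 1 to compound 3 (0.25 log units; that floor lies within the scatter). The first lies beyond the scatter, the second reaches only a floor that lies within it.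

Compound 4 `COc1cc(O)c(CC=C(C)C)c(O)c1C(=O)/C=C/c1ccc(C(F)(F)F)cc1` differs from compound 1 by trifluoromethyl in place of methoxy on an aromatic carbon. For the measured compounds named here, no measured step exchanges a methoxy for a trifluoromethyl, so the two measured steps bear on this change only indirectly: each shows that a change at the methoxy-bearing positions moved the number downward from the limit at compound 1. A downward step of modest size is therefore expected, an at least 1.6-fold lower number from compound 1 to compound 4 (0.22 log units; that floor lies within the scatter). Compound 4 is expected to give 30000 nM in this assay, with a range from 8000 nM to 100000 nM, and with a real chance that only a limit is reported again.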

Compound 4, half-maximal inhibitory concentration: 6800 nM
Estimate against measurement, compound 4: 4.4-fold (0.64 log units) above; measured number outside the range, below it.
By their numbers in this assay, from the lowest: compound 4; then compounds 2 and 3 (each within the scatter of the next). At a limit, above all of these: compound 1.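

In this assay, the exchange at the aromatic carbon para to a large group gives an at least 7.3-fold lower number from compound 1 to compound 4 (0.86 log units; beyond the scatter). The earlier steps shown here moved the methoxy or added a second one, whereas here methoxy leaves the ring and trifluoromethyl, with 0 hydrogen-bond acceptors, takes its place, so compound 4 shows that a methoxy at this position is not required for a measured number in this assay. Compound 1 stands at a limit, so the size of this step is only a floor: the limit of > 50000 nM in this assay, at which 1 of the 4 values shown sits.

The compounds shown leave open whether the lower number follows from the presence of trifluoromethyl or from the loss of methoxy. An unsubstituted carbon at this position, or a chlorine, nitrile, amine or carboxylic acid there, would help separate these two readings.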